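The source may hold more compounds than are shown below. What is called first, only, known or untested is meant among the compounds shown, and "the series" means these compounds.

In a functional assay on PC-3 cells (Homo sapiens) for antiproliferative activity, read by MTT assay, with a stated time of 48 h (a higher number here means a weaker inhibitor, a lower number a stronger inhibitor), compound 3, `O=C(/C=C\Nc1ccc(O)cc1)c1cn(-c2ccccc2)nc1-c1ccc(Cl)cc1`, gives 4430 nM. That is the lowest of the two numbers shown, and the nearest is compound 1, `COc1ccc(N/C=C\C(=O)c2cn(-c3ccccc3)nc2-c2ccccc2)cc1`, which in this assay gives 6400 nM; the two sit within the scatter of each other. Compound 2, `O=C(/C=C\Nc1ccc(F)cc1)c1cn(-c2ccccc2)nc1-c1ccc(Cl)cc1`, is reported in this assay only as a limit, > 50000 nM, and not as a number. For the measured compounds named here, the one measured step, an at least 11-fold lower number from compound 2 to compound 3 (1.05 log units; beyond the scatter), is large and rests on (the limit of > 50000 nM in this assay, at which 1 of the 3 values shown sits).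

Compound 4, `COc1ccc(N/C=C\C(=O)c2cn(-c3ccccc3)nc2-c2ccc(Cl)cc2)cc1`, differs from compound 3 by methyl in place of hydrogen on an oxygen on an aromatic ring. Going by the values given here, no measured step exchanges hydroxy for methoxy on the same core, so none bears on it directly. Compound 1 and compound 3 differ in two places, and their values lie within the scatter of each other, which points to a small step at most. Compound 4 is therefore expected to give 6500 nM, between 2500 nM and 20000 nM, a step of a 1.5-fold higher number from compound 3 to compound 4 (0.17 log units; within the scatter), not beyond the scatter.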

Compound 4, half-maximal inhibitory concentration: 10700 nM
Compound 4: the middle estimate sits 1.6-fold (0.22 log units) below what was measured; the measured number falls inside the stated range.
By their numbers in this assay, from the lowest: compounds 3, 1 and 4 (each within the scatter of the next, the first and the last beyond it). At a limit, above all of these: compound 2.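

In this assay, for the compounds shown here, methyl on the oxygen gives the first direct reading of hydroxy against methoxy on one core: a 2.4-fold higher number from compound 3 to compound 4 (0.38 log units; beyond the scatter), a modest step. With the chloro group kept on the core, chloro in place of hydrogen on an aromatic carbon gives a 1.7-fold higher number from compound 1 to compound 4 (0.22 log units; within the scatter), so this change does not separate the two methoxy compounds. Methoxy, like hydroxy, also reads clear of fluoro at this place, with an at least 4.6-fold lower number from compound 2 to compound 4 (0.66 log units; beyond the scatter), so the large gain seen earlier is not confined to hydroxy, although this step rests on a limit: the limit of > 50000 nM in this assay, at which 1 of the 4 values shown sits.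

As far as these compounds go, how an amine, a carboxylic acid or a longer chain such as ethoxy would read at this place remains open. The compounds shown also leave open whether the hydroxy to methoxy step would hold on the core of compound 1, which carries no chloro group.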